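Anilino-pyranone series: pentyl for isopropyl, compound 4

The source may hold more compounds than are shown below. What is called first, only, known or untested is meant among the compounds shown, and "the series" means these compounds.

Measured compounds in a functional assay on SK-BR-3 cells (Homo sapiens) for cytotoxicity, read by MTT assay, with a stated time of 72 h; on this read-out higher numbers stand for an effect only at larger amounts of compound and lower numbers for an effect already at smaller amounts:
- compound 1 `COc1ccc(Nc2cc(C(C)C)oc(=O)c2)cc1`, which gives only the assay limit > 30 uM
- compound 2 `COc1ccc(Nc2cc(-c3ccc4ccccc4c3)oc(=O)c2)cc1`, which gives 0.13 uM
- compound 3 `O=c1cc(NC2CCCCC2)cc(-c2ccccc2)o1`, which gives 10.9 uM

Compound 1 stands at the limit of this assay and no number is known for it; the position is given by the limit of > 30 uM in this assay, at which 1 of the 3 values shown sits, at which one of the three values sits. Compound 2 and compound 3, which carry an aromatic group on the core in the same place, give numbers below the limit, compound 2 the smaller of the two.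

Compound 4 `CCCCCc1cc(Nc2ccc(OC)cc2)cc(=O)o1` is not yet measured. It differs from compound 1 by pentyl in place of isopropyl on an aromatic carbon; the place and the count of atoms are as given there. For the measured compounds named here, no measured step changes an alkyl chain at this position, so the size of the step is open. Since compound 1 sits at the limit > 30 uM, any step to compound 4 can only be read downward or as none. The expected step is an at least 1.5-fold lower number from compound 1 to compound 4 (0.17 log units; that floor lies within the scatter), small and uncertain, with a fair chance that this assay again reports only a limit. For compound 4 the expected value is 20 uM, with a range from 5 uM to 60 uM.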

Compound 4, concentration for half-maximal effect: 4.93 uM
The estimate for compound 4 lay 4.1-fold (0.61 log units) above the measured number; the measured number lies below the stated range.
By their numbers in this assay, from the lowest: compound 2; then compound 4; then compound 3. At a limit, above all of these: compound 1.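

Pentyl in place of isopropyl gives an at least 6.0-fold lower number from compound 1 to compound 4 (0.78 log units; beyond the scatter), the first reading of a change at this position, and it shows that an alkyl group on this aromatic carbon can shift the result in this assay. The step has only a lower bound, since the value for compound 1 is a limit: the limit of > 30 uM in this assay, at which 1 of the 4 values shown sits.

Compound 4 gives 4.93 uM with no aromatic group at this place, while compound 2, which carries one there, gives 0.13 uM.

How the number follows chain length remains open, as the shown alkyl groups cannot separate length from branching, and a butyl or a longer heptyl chain would bear on this. Also open, going by these compounds, is how a chain ending in an amine or a carboxylic acid would read at this position.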